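A few compounds are considered here, and "the series" means these few. Any claim that something is new, unique, unknown or untested is made for them only; others in the source may bear on it.

Measured compounds:
Compound 1 `COc1ccc(C(=O)/C(=C/c2ccc(Cl)cc2Cl)CCOC(C)=O)cc1` — 69200 nM
Compound 2 `COc1ccc(C(=O)/C(=C/C2CCCCC2)CCOC(C)=O)cc1` — > 100000 nM
Compound 3 `COc1ccc(C(=O)/C(=C/c2ccc(Cl)cc2Cl)CN(C)C(=O)c2ccccc2)cc1` — 32400 nM

The three measured compounds share one core and are tested in a functional assay on A549 cells (Homo sapiens) for inhibition, read by XTT assay, with a stated time of 48 h; on this read-out higher numbers stand for weaker inhibition and lower numbers for stronger inhibition. Compound 1 gives 69200 nM. For compound 2 the read-out is a limit of the assay, > 100000 nM, and not a number; this is the limit described as the limit of > 100000 nM in this assay, at which 1 of the 3 values shown sits. The change from compound 1 to compound 2 is cyclohexyl in place of 2,4-dichlorophenyl on a double-bonded chain carbon bound to a double-bonded chain carbon, and it made an at least 1.4-fold higher number from compound 1 to compound 2 (0.15 log units; that floor lies within the scatter). Compound 3 differs from compound 1 by benzoyl(methyl)amino in place of acetoxymethyl on a saturated chain carbon bound to a double-bonded chain carbon, a change that brought a 2.1-fold lower number from compound 1 to compound 3 (0.33 log units; beyond the scatter). Among the two numbers available, compound 3 stands lowest, with compound 1 nearest to it.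

Compound 4 `COc1ccc(C(=O)/C(=C/C2CCCCC2)CN(C)C(=O)c2ccccc2)cc1` is not yet measured. It differs from compound 3 by cyclohexyl in place of 2,4-dichlorophenyl on a double-bonded chain carbon bound to a double-bonded chain carbon, the same change that was made from compound 1 to compound 2, made at the same place. That earlier step was a higher number, so the step from compound 3 to compound 4 is expected to be a 2.3-fold higher number from compound 3 to compound 4 (0.36 log units; beyond the scatter), resting on the shown an at least 1.4-fold higher number from compound 1 to compound 2 (0.15 log units; that floor lies within the scatter) and on the value of compound 3, 32400 nM. The estimate for compound 4 in this assay is therefore 75000 nM, with a range from 35000 nM to 160000 nM, and a real chance that only a limit is reported.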

Compound 4, half-maximal inhibitory concentration: 69700 nM
The estimate for compound 4 lay 1.1-fold (0.03 log units) above the measured number; low and high end bracket the measured number.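

On the core carrying benzoyl(methyl)amino, in this assay, cyclohexyl in place of 2,4-dichlorophenyl gave a 2.2-fold higher number from compound 3 to compound 4 (0.33 log units; beyond the scatter), a modest step that is readable as a number at both ends. Set beside the same change on the core carrying acetoxymethyl, it points the same way on both cores, but this is one direction seen on two cores, not evidence that the size of the step carries over: the same change on two cores in this assay, an at least 1.4-fold higher number (0.15 log units; that floor lies within the scatter) from compound 1 to compound 2 and a 2.2-fold higher number (0.33 log units; beyond the scatter) from compound 3 to compound 4; the limit leaves it open whether they differ. For compound 2 the result is a limit of the assay, > 100000 nM, and not a number, so the earlier step is known only as a floor, and two cores say nothing about any other core in this series.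

The compounds shown leave open which part of the swap goes with the higher number, since the ring and the two chlorines change together; an unsubstituted phenyl or a 4-chlorophenyl at the same place would separate them. They also leave open whether the change behaves alike on a core with a free amine or a carboxylic acid on the saturated chain carbon in place of the groups seen here.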